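This account rests on a few compounds, and the source may have more. Where it says the series, first, only, none or still open, it means among the compounds named here.

Working notes on the series. Compound 1 `COc1ccc(C[S+]([O-])c2ncccc2C(=O)Nc2ccncc2)c(OC)c1OC`, compound 2 `COc1ccc(C[S+]([O-])c2ncccc2C(=O)Nc2ccncc2)cc1` and compound 3 `COc1cc(OC)c(OC)cc1C[S+]([O-])c1ncccc1C(=O)Nc1ccncc1` share one core and differ in their methoxy pattern. In an ADME assay (on this read-out higher numbers stand for a longer-lived compound and lower numbers for a shorter-lived compound), compound 2 gives 2.14 h, the highest of the two numbers in hand, while compound 1 gives 0.45 h, a gap beyond the usual scatter. Compound 3 sits at the limit of < 0.02 h in this assay, at which 1 of the 3 values shown sits: its result in this assay, < 0.02 h, is a limit of the assay and not a number. Compound 4 `COc1ccc(C[S+]([O-])c2ncccc2C(=O)Nc2ccncc2)c(OCCO)c1` awaits measurement; it differs from compound 2 by 2-hydroxyethoxy in place of hydrogen on an aromatic carbon. Within the data shown here, no step between measured compounds differing in one place exists, so the size of this change rests on a rough reading: both more heavily substituted rings, compound 1 and compound 3, fall well under compound 2, and compound 4 likewise carries an added group. A moderate drop in this assay is expected, a 2.7-fold lower number from compound 2 to compound 4 (0.43 log units; beyond the scatter). Compound 4 is estimated at 0.8 h, likely between 0.2 h and 3 h.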

Compound 4, half-life: < 0.02 h
Compound 4 gave a limit, no number; the forecaster's own chance of this, stated with the estimate: 10%; middle value at least 40-fold (1.60 log units) from the limit.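

Among these compounds, at this position, on an aromatic carbon ortho to a large group and meta to a methoxy group, 2-hydroxyethoxy in place of hydrogen now has a size of its own in this assay with an at least 100-fold lower number from compound 2 to compound 4 (2.02 log units; beyond the scatter) for a change in one place, which the earlier compounds could not give. Going by these compounds, compound 4 gives < 0.02 h, a limit of the assay and not a number, so the step is a bound and its full size stays unknown. The result sits at the floor of the read-out: the limit of < 0.02 h in this assay, at which 2 of the 4 values shown sit.

The compounds shown leave open whether the loss belongs to this chain in particular or to any group on this carbon. A fluorine atom, an amine or a longer chain in the same place would separate these readings.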